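The compounds below may be only part of what the source reports. "The series", "measured", "known", "first", "only" and "open" are said of these compounds alone.

Measured compounds and their values:
compound 1 `COc1ccc(-c2cc(NNC(=O)Nc3cc(Cl)nc(OC)c3)nc3c2cnn3C)cc1` gives 48800 nM
compound 2 `COc1ccc(-c2cc(NNC(=O)Nc3cc(Cl)nc(Cl)c3)nc3c2cnn3C)cc1` gives 18500 nM
compound 3 `CCCOc1cc(NC(=O)NNc2cc(-c3ccc(OC)cc3)c3cnn(C)c3n2)cc(Cl)n1` gives 37200 nM

The read-out is a functional assay on SW620/5-FU cells (Homo sapiens) for cytotoxicity, read by MTT assay, with a stated time of 48 h, in the presence of a further agent that is not named here; on this read-out higher numbers stand for an effect only at larger amounts of compound and lower numbers for an effect already at smaller amounts. Among the three measured compounds, compound 1 stands at the highest number; compound 3 lies close to it, with a 1.3-fold lower number from compound 1 to compound 3 (0.12 log units; within the scatter), while compound 2 sits further off, with a 2.6-fold lower number from compound 1 to compound 2 (0.42 log units; beyond the scatter). The step of a 2.0-fold higher number from compound 2 to compound 3 (0.30 log units; within the scatter) is small.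

Compound 4 `COc1cc(NC(=O)NNc2cc(-c3ccccc3)c3cnn(C)c3n2)cc(Cl)n1` has not been measured. It differs from compound 1 in hydrogen in place of methoxy on an aromatic carbon. For the measured compounds named here, none of the measured steps touches this part of the molecule: the changes from compound 1 to compound 2 and from compound 1 to compound 3 both sit on the other aromatic ring, where chloro or propoxy replaced methoxy or hydrogen. The data therefore offer no direct guide to removing the methoxy group here, and the only well-founded expectation is a number near that of compound 1, with no step beyond the scatter in either direction. Compound 4 is thus estimated at 48800 nM, within a range from 20000 nM to 120000 nM, which would mean an expected step of no change at the digits printed from compound 1 to compound 4 (within the scatter).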

Compound 4, half-maximal effective concentration: 28700 nM
Compound 4: the middle estimate sits 1.7-fold (0.23 log units) above what was measured, within the range that was stated.
By their numbers in this assay, from the lowest: compounds 2, 4, 3 and 1 (each within the scatter of the next, the first and the last beyond it).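

For the compounds shown here, all the earlier compounds carry the 4-methoxyphenyl group, so compound 4 gives the first look at this position. In this assay the change from 4-methoxyphenyl to phenyl gives a 1.7-fold lower number from compound 1 to compound 4 (0.23 log units; within the scatter), so for this one pair, the methoxy group para to a large group can give way to hydrogen without a step beyond the usual scatter. No supporting information bears on this result.

Going by these compounds, only methoxy and hydrogen can be compared at this place, so it remains open how a group such as an amine or a hydroxyl would behave there. On these data alone, it is also open whether the same change would give a similar step in compounds carrying the chloro of compound 2 or the propoxy of compound 3 in place of the methoxy on the other ring.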